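Selenium to Sulfur on a Shared Core: One Expected Number

The compounds below may be only part of what the source reports. "The series", "measured", "known", "first", "only" and "open" are said of these compounds alone.

Compound 1 `C[Se]/C(=N\C(=O)c1cc2ccccc2s1)NC(=O)c1cc2ccccc2s1` — 80600 nM
Compound 2 `CS/C(=N\C(=O)c1sccc1Cl)NC(=O)c1sccc1Cl` — a limit, > 100000 nM

Among the measured compounds shown here, in a functional assay on MCF7 cells (Homo sapiens) for cytotoxicity, read by MTT assay, with a stated time of 72 h (a lower number here means that less compound is tolerated, a higher number that more compound is tolerated), compound 1 gives 80600 nM, the only true number in the set. Compound 2 reaches only a limit of the assay in this assay, > 100000 nM. the limit of > 100000 nM in this assay, at which 1 of the 2 values shown sits, marks where that value sits.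

Compound 3 `CS/C(=N\C(=O)c1cc2ccccc2s1)NC(=O)c1cc2ccccc2s1` has not yet been measured. It differs from compound 1 in one place:

a group of 2 heavy atoms (1 carbon, 1 sulfur; no ring) in place of a group of 2 heavy atoms (1 carbon, 1 selenium; no ring), on a carbon with a double bond to nitrogen

For the measured compounds named here, no measured pair isolates this change, so its size cannot be read from the numbers. Compound 2 also carries methylsulfanyl, though on a different core, and it sits at a limit rather than a number. Compound 3 is therefore expected to come out at 100000 nM, with a range from 40000 nM to 250000 nM. The expected step of a 1.2-fold higher number from compound 1 to compound 3 (0.09 log units; within the scatter) is a modest move toward a higher number, at the edge of the scatter, with a real chance that only a limit is reported.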

Compound 3, concentration lethal to 50% of the cells: 78500 nM
The estimate for compound 3 lay 1.3-fold (0.11 log units) above the measured number, and the stated range covers the measured number.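

On the shared core, the exchange of the selenium-bearing group for methylsulfanyl now has a measured size of a 1.0-fold lower number from compound 1 to compound 3 (0.01 log units; within the scatter) in this assay. Among the compounds shown here, on a carbon with a double bond to nitrogen, this read-out therefore does not separate the two groups, which the earlier compounds could not show, as they held no pair differing only in this place. Nothing at hand gives a reason for this result.

Still open, going by these compounds, is whether an amine or a longer chain in the same place would leave the number unmoved. Also open is whether the exchange behaves alike on another core, a question compound 2 does not settle, since its value is a limit of the assay and no partner differing from it in this one place is shown.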